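The compounds below may be only part of what the source reports. "The series", "measured", "known", "first", "only" and "open" are said of these compounds alone.

Three compounds have been measured in an assay on isolated protein for inhibition of DNA topoisomerase 1 (Homo sapiens), with a stated time of 30 min, tested at 100 uM; a higher number here means more inhibition at the concentration tested (going by the name of the read-out), a lower number less inhibition:
compound 1 `Clc1ccc(-c2cc(-c3ccoc3)cc(-c3ccco3)n2)s1` gives 9.6%;
compound 2 `Clc1cccc(-c2cc(-c3ccoc3)cc(-c3ccc(Cl)s3)n2)c1` gives 2.1%;
compound 3 `Cc1ccsc1-c1cc(-c2ccc(Cl)o2)cc(-c2ccco2)n1` gives 7.8%.

All three numbers are small and lie within the scatter of one another, so none of them can be ranked against the others. For the measured compounds named here, the one pair that differs in a single place is compound 1 and compound 2, where the change is 3-chlorophenyl in place of furan-2-yl on an aromatic carbon and the step is a number 7.5 percentage points lower from compound 1 to compound 2 (within the scatter).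

Compound 4 `Cc1ccsc1-c1cc(-c2ccc(Cl)o2)cc(-c2cccc(Cl)c2)n1` has not yet been measured. It differs from compound 3 by 3-chlorophenyl in place of furan-2-yl on an aromatic carbon. The difference between the core of compound 1 and the core of compound 3 is not broken down here. Around the place of the change, compound 1 carries a 5-chlorothiophen-2-yl group and a furan-3-yl group, while compound 3 carries a 3-methylthiophen-2-yl group and a 5-chlorofuran-2-yl group, so the two changes are the same kind of change, not the same.

Because a number 7.5 percentage points lower from compound 1 to compound 2 (within the scatter) stayed within the scatter, a step of about the same size, a number 4.8 percentage points lower from compound 3 to compound 4 (within the scatter), is expected in this assay. Compound 4 is thus estimated at 3%, between 0% and 14%.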

Compound 4, a percentage reported as inhibition, at one concentration (the size of the read-out at that concentration, not a potency): 5.9%
Compound 4: the middle estimate sits 2.9 percentage points below what was measured; low and high end bracket the measured number.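

In this assay, putting 3-chlorophenyl in place of furan-2-yl gives a number 1.9 percentage points lower from compound 3 to compound 4 (within the scatter). Set beside the earlier case, the same change gives steps that cannot be told apart on the two cores: the same change on two cores in this assay, a number 7.5 percentage points lower (within the scatter) from compound 1 to compound 2 and a number 1.9 percentage points lower (within the scatter) from compound 3 to compound 4, 5.6 percentage points apart, within the scatter of two such steps This shows only that the change moved the number by no more than the usual scatter on either core, so it does not show that the change has any real effect, and two cores with small readings cannot show how it would behave on a core with clear inhibition.

The compounds shown carry only aromatic rings on the central ring, with chlorine or methyl as the sole additions, so it remains open whether an amine, a carboxylic acid or a longer chain in place of furan-2-yl would read any differently in this assay. As far as these compounds go, it also remains open whether any compound of this series gives inhibition clearly beyond the scatter, which is what a real comparison of steps would need.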